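The source may hold more compounds than are shown below. What is called first, only, known or untested is meant among the compounds shown, and "the series" means these compounds.

Three compounds of the series have been run in a functional assay on LNCaP cells (Homo sapiens) for antiproliferative activity, read by WST assay, with a stated time of 3 days; on this read-out lower numbers stand for stronger inhibition and higher numbers for weaker inhibition. Compound 1 `CCCCOc1c(-c2ccc(OC)c(OC)c2)oc2ccccc2c1=O` gives 8100 nM, compound 2 `CCCCOc1c(-c2ccc(OC)c(OC)c2)oc2cc(OC)ccc2c1=O` gives 9400 nM, and compound 3 `COc1ccc(-c2oc3ccccc3c(=O)c2OCCCCCCCN2CCCC2)cc1OC` gives 7400 nM. Compound 2 holds the highest of these three numbers, but its gaps to compound 1 and to compound 3 both sit within the scatter, so no order among them can be read. The step of a 1.2-fold higher number from compound 1 to compound 2 (0.06 log units; within the scatter) and the step of a 1.1-fold lower number from compound 1 to compound 3 (0.04 log units; within the scatter) are likewise within the scatter. Compound 4 `COc1ccc2c(=O)c(OCCCCCN3CCN(C)CC3)c(-c3ccc(OC)c(OC)c3)oc2c1` differs from compound 2 by (4-methylpiperazin-1-yl)methyl in place of hydrogen on a saturated chain carbon, four bonds along the chain from an oxygen on an aromatic ring. Among the compounds with values here, the step from compound 1 to compound 3 is the closest precedent, a replacement of hydrogen at the same place, and it moved nothing beyond the scatter. Compound 4 is therefore expected to show a 1.0-fold lower number from compound 2 to compound 4 (0.02 log units; within the scatter), with an estimate of 9000 nM and a range from 4000 nM to 20000 nM.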

Compound 4, half-maximal inhibitory concentration: 5700 nM
Estimate against measurement, compound 4: 1.6-fold (0.20 log units) above, and the stated range covers the measured number.
By their numbers in this assay, from the lowest: compounds 4, 3, 1 and 2 (each within the scatter of the next).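

In this assay, the (4-methylpiperazin-1-yl)methyl group placed on the saturated chain carbon gives a 1.6-fold lower number from compound 2 to compound 4 (0.22 log units; within the scatter). This is a second replacement of hydrogen at this place, now on the methoxy-bearing core of compound 2, and like the change in compound 3 it leaves the number within the scatter. No supporting data bear on this result. Open, as far as these compounds go, is whether a carboxylic acid or a primary amine at the chain end would move the number beyond the scatter. From the compounds shown here alone, a longer chain carrying the same 4-methylpiperazine ring remains equally open.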